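Tetrazole for carboxylate on the quinolinylmethoxyphenyl chain

This account rests on a few compounds, and the source may have more. Where it says the series, first, only, none or still open, it means among the compounds named here.

Measured so far:
compound 1 `O=C(O)CCCCc1cccc(OCc2ccc3ccccc3n2)c1`: 100 nM
compound 2 `CC(Cc1cccc(OCc2ccc3ccccc3n2)c1)CC(C)C(=O)O`: 24 nM

Two compounds share the core shown above and have been tested in an assay on membranes from lung (Cavia porcellus) for binding affinity to cysteinyl leukotriene receptor (Homo sapiens); on this read-out lower numbers stand for stronger inhibition and higher numbers for weaker inhibition. Compound 1 gives 100 nM, and compound 2 gives 24 nM. Among the compounds with values here, the one step between them, a 4.2-fold lower number from compound 1 to compound 2 (0.62 log units; beyond the scatter), is the only measured change, and it concerns the side chain: 3-carboxy-1-methylbutyl in place of 3-carboxypropyl on a saturated chain carbon bound to an aromatic carbon. Within the data shown here, on these two numbers compound 2 stands lowest, with compound 1 the only neighbour.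

Compound 3 `CC(CCc1nnn[nH]1)Cc1cccc(OCc2ccc3ccccc3n2)c1` has not yet been measured. It differs from compound 2 by (1H-tetrazol-5-yl)methyl in place of 1-carboxyethyl on a saturated chain carbon, three bonds along the chain from an aromatic carbon. Read one bond further out, the change is 3-carboxy-1-methylbutyl to 3-(1H-tetrazol-5-yl)-1-methylpropyl. Among the measured compounds shown here, no measured step touches this part of the molecule; the step from compound 1 to compound 2 altered the chain branching while keeping the carboxylic end, so it gives no direct guide. In the absence of such a precedent, compound 3 is expected to stay near compound 2, with an estimated step of a 1.3-fold higher number from compound 2 to compound 3 (0.10 log units; within the scatter). Compound 3 is therefore estimated at 30 nM, within a range of 8 nM to 120 nM.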

Compound 3, inhibition constant: 34 nM
For compound 3 the middle estimate is 1.1-fold (0.05 log units) below the measured one, and the stated range covers the measured number.
By their numbers in this assay, from the lowest: compounds 2 and 3 (each within the scatter of the next); then compound 1.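

In this assay, (1H-tetrazol-5-yl)methyl in place of 1-carboxyethyl on a saturated chain carbon, three bonds along the chain from an aromatic carbon, gives a 1.4-fold higher number from compound 2 to compound 3 (0.15 log units; within the scatter) and so leaves the reading inside the scatter, which shows that at this place a carboxylic acid end is not required to hold the level of compound 2. Compound 3 also stands clear of the unbranched acid, with a 2.9-fold lower number from compound 1 to compound 3 (0.47 log units; beyond the scatter) as a modest step, so the advantage over compound 1 survives without any carboxyl group in the molecule. Nothing measured here bears on why the two chain ends read alike.

Going by these compounds, the change from compound 2 to compound 3 replaces the acid and alters the branching of the chain end in one move, so the share of each stays open, as does the reading of the tetrazole on the unbranched chain of compound 1. On these data alone, how a sulfonamide or a primary amide at the same chain end, or a longer chain carrying the tetrazole, would read also remains open.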